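Swapping Ethoxy for Methylsulfonyl on a Stomach Inhibitor Series

A few compounds are considered here, and "the series" means these few. Any claim that something is new, unique, unknown or untested is made for them only; others in the source may bear on it.

Of the compounds shown here, three sharing one core have been tested in a functional assay on the whole organism (stomach) for inhibition, with Canis familiaris (Canis lupus familiaris) as the target, at a dose of 5 mg/kg by the intravenous route; a higher number here means a stronger effect of the compound at the dose given, a lower number a weaker effect. Compound 1 `CC(=O)c1c(C)nc2c(OCc3ccccc3)cccn12` gives 9%, compound 2 `Cc1nc2c(OCc3ccccc3)cccn2c1C#N` gives 4%, and compound 3 `CCOCc1c(C)nc2c(OCc3ccccc3)cccn12` gives 35%. The move a number 5 percentage points lower from compound 1 to compound 2 (within the scatter) is too small to read as a real change. By contrast, a number 26 percentage points higher from compound 1 to compound 3 (beyond the scatter) and a number 31 percentage points higher from compound 2 to compound 3 (beyond the scatter) both exceed the scatter, so compound 3 stands clearly highest of the three, with compound 1 nearest and compound 2 furthest behind.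

Compound 4 `Cc1nc2c(OCc3ccccc3)cccn2c1CS(C)(=O)=O` has not yet been measured. It differs from compound 3 in one place: methylsulfonyl in place of ethoxy on a saturated chain carbon bound to an aromatic carbon. For the measured compounds named here, no measured step involves a methylsulfonyl group, so there is no direct guide. What the measured steps do show, through a number 26 percentage points higher from compound 1 to compound 3 (beyond the scatter) and a number 31 percentage points higher from compound 2 to compound 3 (beyond the scatter), is that the group on this part of the core moves the read-out well beyond the scatter, and that only the ethoxymethyl compound reached a high number while the other two variants stayed low. On that basis a downward step is expected, of moderate size, estimated as a number 15 percentage points lower from compound 3 to compound 4 (beyond the scatter). Compound 4 is therefore estimated to give 20% in this assay, with a likely range from 3% to 45%.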

Compound 4, a percentage reported as inhibition, in the whole organism at one dose (the size of the read-out at that dose, not a potency): 0%
The estimate for compound 4 lay 20 percentage points above the measured number, and the stated range ends above it.
By their numbers in this assay, from the lowest: compounds 4, 2 and 1 (each within the scatter of the next); then compound 3.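

The saturated chain carbon bound to an aromatic carbon is present in both compound 3 and compound 4, so a chain carbon at this place is not enough by itself to keep the effect in this assay. What it carries matters: the change from ethoxy to methylsulfonyl gives a large drop (a number 35 percentage points lower from compound 3 to compound 4 (beyond the scatter)), and compound 4 reads (0%). For the compounds shown here, the (methylsulfonyl)methyl group also cannot be told apart from the two groups tested earlier on the aromatic carbon, nitrile (a number 4 percentage points lower from compound 2 to compound 4 (within the scatter)) and acetyl (a number 9 percentage points lower from compound 1 to compound 4 (within the scatter)), which leaves ethoxymethyl in compound 3 as the only group of the four with a clear effect at this dose. Nothing available here bears on what lies behind this difference.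

With only one ether in the set, the compounds shown leave open how narrowly the effect depends on ethoxy. A methoxy group, a longer propoxy chain, a hydroxyl group or an amine on the same saturated chain carbon would show whether the oxygen, the ethyl chain or both go with the higher number.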